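The compounds below may be only part of what the source reports. "The series", "measured", "known", "first", "only" and "open" are said of these compounds alone.

In a functional assay on L1210 cells (Mus musculus) for antiproliferative activity, with a stated time of 48 h (a higher number here means a weaker inhibitor, a lower number a stronger inhibitor), compound 1 `C=C(Br)C(=O)Nc1ccc(C(=O)/C=C/c2ccccc2)cc1` gives 880 nM and compound 2 `C=C(Br)C(=O)Nc1ccc(C(=O)/C=C/c2ccc(N(C)C)cc2)cc1` gives 1900 nM, so compound 2 holds the higher, weaker number of the two. Compound 3 `CN(C)c1ccc(/C=C/C(=O)c2ccc(N)cc2)cc1` differs from compound 2 in one place: hydrogen in place of (1-bromoethenyl)carbonyl on a nitrogen on an aromatic ring. Put simply, hydrogen stands in place of (1-bromoethenyl)carbonyl on a nitrogen on an aromatic ring. Among the measured compounds shown here, only one measured step exists, a 2.2-fold higher number from compound 1 to compound 2 (0.33 log units; beyond the scatter), and it is modest. It swaps dimethylamino for hydrogen on an aromatic carbon, so it bears on this change only loosely. Both measured compounds carry (1-bromoethenyl)carbonyl, and no measurement shows what losing it does. Since far more of the molecule goes here than changed in that step, a larger move towards a weaker number is expected, beyond the scatter. The expected move is a 7.9-fold higher number from compound 2 to compound 3 (0.90 log units; beyond the scatter). For compound 3 the estimate is 15000 nM, with an expected range of 5000 nM to 50000 nM.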

Compound 3, half-maximal inhibitory concentration: 67000 nM
The estimate for compound 3 lay 4.5-fold (0.65 log units) below the measured number; measured number outside the range, above it.
By their numbers in this assay, from the lowest: compound 1; then compound 2; then compound 3.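

In this assay, replacing the (1-bromoethenyl)carbonyl on the nitrogen with hydrogen gives a 35-fold higher number from compound 2 to compound 3 (1.55 log units; beyond the scatter), a large step. Among the compounds shown here, the only earlier step, a 2.2-fold higher number from compound 1 to compound 2 (0.33 log units; beyond the scatter), was modest and involved a change on an aromatic carbon, so this is the first direct sign that the group on this nitrogen matters strongly for the antiproliferative activity of compound 2. No available evidence explains the size of this loss.

The compounds shown leave open whether the bromine or the rest of the group carries the effect; an acetyl or a plain propenoyl group on the same nitrogen would help separate the two. From the compounds shown here alone, it also remains open whether the same replacement would have a similar effect on the core of compound 1, which lacks dimethylamino.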